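A few compounds are considered here, and "the series" means these few. Any claim that something is new, unique, unknown or untested is made for them only; others in the source may bear on it.

Measured in a functional assay on Hs-578T cells (Homo sapiens) for antiproliferative activity; a lower number here means a stronger inhibitor of growth, a higher number a weaker inhibitor of growth:
- compound 1 `COCCCCCCCCCCC/C=C1\CC(CO)(COC(=O)C(C)(C)C)OC1=O`: 7.34 ug/mL
- compound 2 `CCCCCOCCCCCCC/C=C1\CC(CO)(COC(=O)C(C)(C)C)OC1=O`: 3 ug/mL
- compound 3 `CC(C)(C)C(=O)OCC1(CO)C/C(=C\CCCCCCCCCCCO)C(=O)O1`: > 10 ug/mL

The value of compound 3 is a limit of this assay and not a number.

The next structure, compound 4 `CC(=O)OCCCCCCCCCCCCCCC/C=C1\CC(CO)(COC(=O)C(C)(C)C)OC1=O`, keeps the shared core and alters the chain: 4-acetoxybutyl in place of hydroxy on a saturated chain carbon, ten or more bonds along the chain from a double-bonded chain carbon.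

Within the data shown here, two measured steps bear on this, since both end at the hydroxy compound. The larger, an at least 3.3-fold higher number from compound 2 to compound 3 (0.52 log units; beyond the scatter), is at least modest and beyond the scatter. The other, an at least 1.3-fold higher number from compound 1 to compound 3 (0.13 log units; that floor lies within the scatter), has a floor within the scatter. Neither compound 1 nor compound 2 carries an acetoxy group, so these steps guide only loosely. Read in reverse, they suggest that losing the hydroxy end should bring a modest move to a lower number.

The expected step is an at least 2.5-fold lower number from compound 3 to compound 4 (0.39 log units; beyond the scatter).

For compound 4 the estimated value is 4 ug/mL, with an expected range from 1.5 ug/mL to 10 ug/mL.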

Compound 4, concentration for 50% growth inhibition: > 10 ug/mL
Compound 4 was reported as a limit; the forecaster's own chance of this, stated with the estimate: 20%; at least 2.5-fold (0.39 log units) between middle value and limit.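

In this assay compound 4 gives > 10 ug/mL, which is a limit of the assay and not a number. Putting 4-acetoxybutyl on the hydroxy end therefore does not by itself yield a measured value, and the comparisons with the ether compounds read an at least 3.3-fold higher number from compound 2 to compound 4 (0.52 log units; beyond the scatter) and an at least 1.3-fold higher number from compound 1 to compound 4 (0.13 log units; that floor lies within the scatter), so only the first of these floors clears the usual scatter. The step between compound 3 and compound 4 cannot be read, because both compounds sit at the same limit: the limit of > 10 ug/mL in this assay, at which 2 of the 4 values shown sit.

As far as these compounds go, how compound 3 and compound 4 rank against each other stays open. Also open, from the compounds shown here alone, is whether a different chain end, such as an amine or a carboxylic acid, would give a measured value at this position.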